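A few compounds are considered here, and "the series" means these few. Any claim that something is new, unique, unknown or untested is made for them only; others in the source may bear on it.

Three measured esters share one core. Compound 1 `COc1cc(/C=C/C(=O)O)ccc1OC(=O)c1nc(C)c(C)nc1C` gives 69400 nM in a functional assay on EA.hy 926 cells (Homo sapiens) for cytotoxicity, read by MTT assay, with stated times of 24 h and 12 h; a lower number here means that less compound is needed, a higher number that more compound is needed for the effect. Compound 2 `COc1cc(/C=C/C(=O)O)cc(OC)c1OC(=O)c1nc(C)c(C)nc1C` gives 34700 nM in this assay, and compound 3 `CCOC(=O)/C=C/c1ccc(OC(=O)c2nc(C)c(C)nc2C)c(OC)c1` gives 38600 nM. The change hydrogen in place of methoxy on an aromatic carbon brought a 2.0-fold higher number from compound 2 to compound 1 (0.30 log units; within the scatter), and the further change of ethyl in place of hydrogen on an oxygen next to a carbonyl group brought a 1.8-fold lower number from compound 1 to compound 3 (0.25 log units; within the scatter). How the core of compound 3 differs from that of compound 2 is not broken down here.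

Compound 4 `CCOC(=O)/C=C/c1ccc(OC(=O)c2nc(C)c(C)nc2C)cc1` is not yet measured. It differs from compound 3 by hydrogen in place of methoxy on an aromatic carbon, the same kind of change as from compound 2 to compound 1, though there the place was also meta to a methoxy group and the unsaturated chain was a 2-carboxyethenyl group. Because a 2.0-fold higher number from compound 2 to compound 1 (0.30 log units; within the scatter) stayed within the scatter, compound 4 is expected to show a 1.8-fold higher number from compound 3 to compound 4 (0.26 log units; within the scatter), giving an estimate of 70000 nM with a range from 35000 nM to 140000 nM.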

Compound 4, half-maximal effective concentration: 34900 nM
Compound 4: middle estimate off by 2.0-fold (0.30 log units), on the high side; the measured number lies below the stated range.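

In this assay, hydrogen in place of methoxy on an aromatic carbon of the ethyl ester core brought a 1.1-fold lower number from compound 3 to compound 4 (0.04 log units; within the scatter) and so stayed within the scatter, as it had on the carboxylic acid core. The two steps do not differ beyond what repeated measurements would give: the same change on two cores in this assay, a 2.0-fold higher number (0.30 log units; within the scatter) from compound 2 to compound 1 and a 1.1-fold lower number (0.04 log units; within the scatter) from compound 3 to compound 4, 2.2-fold (0.34 log units) apart, within the scatter of two such steps. This shows that the change can be carried between these two cores without a detectable difference, but it rests on two small steps and does not show a shared effect of the change on either core.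

The compounds shown leave open what an amine or a fluorine in place of the methoxy group would give. Also open, as far as these compounds go, is whether the step holds when the unsaturated chain ends in an amide.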